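This account rests on a few compounds, and the source may have more. Where it says the series, first, only, none or still open, it means among the compounds named here.

Compound 1 `COc1ccc2nc(-c3ccc(N/C=C\C(=O)c4cc(OC)c(OC)c(OC)c4)c(C)c3)sc2c1` and compound 2 `COc1ccc2nc(-c3ccc(N/C=C\C(=O)c4cc(OC)c(OC)c(OC)c4)cc3)sc2c1` share one core, while compound 3 `COc1cc(OC)c2sc(-c3ccc(N/C=C\C(=O)c4cc(OC)c(OC)c(OC)c4)c(C)c3)nc2c1` and compound 4 `COc1cc(OC)c2sc(-c3ccc(N/C=C\C(=O)c4cc(OC)c(OC)c(OC)c4)cc3)nc2c1` share another; the difference between the two cores is not broken down here. In a functional assay on MIA PaCa-2 cells (Homo sapiens) for antiproliferative activity, read by sulforhodamine B assay, with a stated time of 48 h (on this read-out lower numbers stand for stronger inhibition and higher numbers for weaker inhibition), compound 1 gives 10000 nM, compound 2 gives 31100 nM and compound 3 gives 17000 nM. The change from compound 1 to compound 2 is hydrogen in place of methyl on an aromatic carbon, and it brought a 3.1-fold higher number from compound 1 to compound 2 (0.49 log units; beyond the scatter). The change from compound 3 to compound 4 is the same kind of change, (hydrogen in place of methyl on an aromatic carbon), the place differing only in that the large group there is named as a 6-methoxy-1,3-benzothiazol-2-yl group in the first pair. Because compound 1 to compound 2 gave a 3.1-fold higher number from compound 1 to compound 2 (0.49 log units; beyond the scatter), a similar step, a 2.9-fold higher number from compound 3 to compound 4 (0.47 log units; beyond the scatter), is expected here. Compound 4 is therefore estimated at 50000 nM in this assay, between 20000 nM and 120000 nM.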

Compound 4, half-maximal inhibitory concentration: 26800 nM
The estimate for compound 4 lay 1.9-fold (0.27 log units) above the measured number; measured number inside the range.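

Putting hydrogen in place of the methyl group gave a 1.6-fold higher number from compound 3 to compound 4 (0.20 log units; within the scatter) in this assay. Set beside the earlier step, this one does not differ from it by more than two such steps would be expected to scatter: the same change on two cores in this assay, a 3.1-fold higher number (0.49 log units; beyond the scatter) from compound 1 to compound 2 and a 1.6-fold higher number (0.20 log units; within the scatter) from compound 3 to compound 4, 2.0-fold (0.30 log units) apart, within the scatter of two such steps. The data therefore give no sign that the change behaves differently on the two cores, but two pairs, one of them with a step within the scatter, cannot prove that it behaves alike.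

The compounds shown leave open what an ethyl group or a chlorine atom would do on the same aromatic carbon. They also leave open whether the step would carry over to any further core.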